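Replacing a Nitrophenyl with a Fluorophenyl on a Decyl Chalcone

This account rests on a few compounds, and the source may have more. Where it says the series, first, only, none or still open, it means among the compounds named here.

The measured compounds:
compound 1 `CCCCCCCCn1cc(/C=C/C(=O)c2ccc(NC(=O)CN3CCN(c4ccccc4F)CC3)cc2)nn1`, 60300 nM
compound 2 `CCCCCCCCn1cc(/C=C/C(=O)c2ccc(NC(=O)CN3CCN(c4ccc([N+](=O)[O-])cc4)CC3)cc2)nn1`, 51400 nM
compound 3 `CCCCCCCCCCn1cc(/C=C/C(=O)c2ccc(NC(=O)CN3CCN(c4ccc([N+](=O)[O-])cc4)CC3)cc2)nn1`, 40900 nM

Three compounds sharing one core were tested in a functional assay on SK-N-SH cells (Homo sapiens) for inhibition, read by MTT assay; a lower number here means a stronger inhibitor, a higher number a weaker inhibitor. Compound 2 gives 51400 nM, compound 1 gives 60300 nM and compound 3 gives 40900 nM. The three values lie close together, and none of the steps among them is beyond the usual scatter.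

Compound 1 differs from compound 2 by 2-fluorophenyl in place of 4-nitrophenyl on an amine nitrogen in a ring, and this gave a 1.2-fold higher number from compound 2 to compound 1 (0.07 log units; within the scatter). Compound 3 differs from compound 2 by ethyl in place of hydrogen on a saturated chain carbon, eight bonds along the chain from an aromatic nitrogen, and this gave a 1.3-fold lower number from compound 2 to compound 3 (0.10 log units; within the scatter).

The unmeasured compound 4 `CCCCCCCCCCn1cc(/C=C/C(=O)c2ccc(NC(=O)CN3CCN(c4ccccc4F)CC3)cc2)nn1` carries the same change that turned compound 2 into compound 1, but now on the core of compound 3: 2-fluorophenyl in place of 4-nitrophenyl on an amine nitrogen in a ring. The place of the change is described in the same words for both pairs, so this is the same kind of change on a core that differs by the ethyl described above. Since the earlier step was within the scatter, the step from compound 3 to compound 4 is expected to be small as well, estimated at a 1.2-fold higher number from compound 3 to compound 4 (0.07 log units; within the scatter). This expectation rests on the step of a 1.2-fold higher number from compound 2 to compound 1 (0.07 log units; within the scatter) and on compound 3, which gives 40900 nM. Compound 4 is therefore expected to give about 48000 nM in this assay, with a likely range from 25000 nM to 95000 nM.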

Compound 4, half-maximal inhibitory concentration: 34400 nM
Compound 4: the middle estimate sits 1.4-fold (0.14 log units) above what was measured; low and high end bracket the measured number.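

In this assay, 2-fluorophenyl in place of 4-nitrophenyl on the core of compound 3 gives a 1.2-fold lower number from compound 3 to compound 4 (0.08 log units; within the scatter), and this step does not differ from the same change on the shorter chain: the same change on two cores in this assay, a 1.2-fold higher number (0.07 log units; within the scatter) from compound 2 to compound 1 and a 1.2-fold lower number (0.08 log units; within the scatter) from compound 3 to compound 4, 1.4-fold (0.14 log units) apart, within the scatter of two such steps. The ethyl on the saturated chain, now read with 2-fluorophenyl in place, gives a 1.8-fold lower number from compound 1 to compound 4 (0.24 log units; within the scatter), and it also agrees with its earlier counterpart: the same change on two cores in this assay, a 1.3-fold lower number (0.10 log units; within the scatter) from compound 2 to compound 3 and a 1.8-fold lower number (0.24 log units; within the scatter) from compound 1 to compound 4, 1.4-fold (0.14 log units) apart, within the scatter of two such steps. Among these compounds, both changes therefore carry from one core to the other without a detectable difference, but every step here lies within the scatter, so this agreement shows only that neither change produced a measurable shift on either core, not that either has a real and transferable effect.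

The compounds shown cover only 4-nitrophenyl and 2-fluorophenyl on the ring nitrogen and only the octyl and decyl chains, all with numbers of similar size in this one assay. As far as these compounds go, it remains open whether another group on that nitrogen, such as an unsubstituted phenyl or a 4-methoxyphenyl, or a different chain, such as butyl or dodecyl, would give a step beyond the scatter, and whether such a step would then carry between cores.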